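The source may report more compounds than this note shows. Statements on the series, on what has been measured and on what is new or still open speak of the compounds shown alone.

In a functional assay on the whole organism with Mus musculus as the target (a lower number here means that less compound is needed, a higher number that more compound is needed for the effect), compound 1 (`CNC(=O)[C@H](CCSC)NCc1ccc(OCc2ccccc2)cc1`) gives 239 mg/kg as its dose for half-maximal effect. In the same test compound 2 (`C[C@@H](NCc1ccc(Oc2ccccc2)cc1)C(N)=O`) gives 64 mg/kg and compound 3 (`CNC(=O)[C@@H](CO)NCc1ccc(OCc2cccc(OC)c2)cc1`) gives 109 mg/kg (the reference point for what follows). Compound 3 lies within the usual scatter of compound 2, so the two cannot be told apart. Compound 1, by contrast, needs a higher dose than compound 3, and that gap lies beyond the scatter.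

Compound 4 (`CNC(=O)[C@@H](CO)NCc1ccc(OCc2cccc(F)c2)cc1`) has not yet been measured. It carries fluoro in place of methoxy on an aromatic carbon, meta to a large group (fluoro in place of methoxy on an aromatic carbon). Among the compounds with values here, no pair of measured compounds isolates this exchange, so the data give no direct guide to its effect. In this assay the expected shift towards a lower number stays within the scatter (a 1.5-fold lower number from compound 3 to compound 4 (0.16 log units; within the scatter)). Compound 4 is estimated at 75 mg/kg (expected range 32 mg/kg to 170 mg/kg).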

Compound 4, dose for half-maximal effect: 25.1 mg/kg
Estimate against measurement, compound 4: 3.0-fold (0.48 log units) above; the whole stated range lies above it.
By their numbers in this assay, from the lowest: compound 4; then compounds 2 and 3 (each within the scatter of the next); then compound 1.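

In this assay, the exchange of fluoro for methoxy on an aromatic carbon, meta to a large group, gives a 4.3-fold lower number from compound 3 to compound 4 (0.64 log units; beyond the scatter), a step beyond the usual scatter. Within the data shown here, this is the first comparison that isolates one place, and it shows that the dose responds to the group at this position, with the rest of the molecule unchanged. The exchange replaces 3-methoxyphenyl with 3-fluorophenyl, losing one hydrogen-bond acceptor and going from two heavy atoms to one, but no measurement shown explains why the number falls.

From the compounds shown here alone, whether chloro, trifluoromethyl, a nitrile or plain hydrogen at this place would give a lower or a higher number remains open. So does whether fluoro would give a similar step at another carbon of the same ring.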